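The source may hold more compounds than are shown below. What is called first, only, known or untested is meant among the compounds shown, and "the series" means these compounds.

Working notes on the series.

Among the compounds with values here, compound 3 `CN1CCN(Cc2ccc(-c3ccc(CCC(=O)c4ncc(-c5cccc(C(=O)O)n5)o4)cc3)cc2)CC1` gives 1200 nM in an assay for inhibition of Fatty-acid amide hydrolase 1 (Rattus norvegicus) (on this read-out lower numbers stand for stronger inhibition and higher numbers for weaker inhibition), and stands highest of the three numbers measured so far. Its nearest neighbour is compound 1 `O=C(O)c1cccc(-c2cnc(C(=O)CCc3ccc(-c4ccc(CN5CCCCC5)cc4)cc3)o2)n1`, which gives 44 nM in this assay; the furthest is compound 2 `COC(=O)c1cccc(-c2cnc(C(=O)CCc3ccc(-c4ccc(CN5CCCC5)cc4)cc3)o2)n1`, which gives 18 nM in this assay. Within the data shown here, the one measured step that touches compound 3 is a 27-fold higher number from compound 1 to compound 3 (1.44 log units; beyond the scatter), a large loss when the methylpiperazine replaces the piperidine at the same position.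

Compound 4 `O=C(O)c1cccc(-c2cnc(C(=O)CCc3ccc(-c4ccc(CN5CCCC5)cc4)cc3)o2)n1` differs from compound 3 in one place: pyrrolidin-1-yl in place of 4-methylpiperazin-1-yl on a saturated chain carbon bound to an aromatic carbon. This change removes the group that, in the step from compound 1 to compound 3, carried the large loss, and puts in its place a ring that is present in compound 2, whose number in this assay is the lowest shown. Compound 2 and compound 4 are not one step apart, as they also differ in the ester against the acid; the values of compound 1 and compound 2 simply show that both the piperidine and the pyrrolidine variants sit far below compound 3. The expectation for compound 4 in this assay is therefore a drop of about a 30-fold lower number from compound 3 to compound 4 (1.48 log units; beyond the scatter), a step beyond the scatter, back toward the range of compound 1 and compound 2. Compound 4 is estimated at 40 nM, with a range from 12 nM to 130 nM.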

Compound 4, inhibition constant: 130 nM
Beside the measured number, compound 4's estimate is 3.3-fold (0.51 log units) below it, and the stated range covers the measured number.
By their numbers in this assay, from the lowest: compound 2; then compound 1; then compound 4; then compound 3.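

In this assay, the step of a 9.2-fold lower number from compound 3 to compound 4 (0.97 log units; beyond the scatter) wins back a large part of what a 27-fold higher number from compound 1 to compound 3 (1.44 log units; beyond the scatter) lost, so the loss goes with the 4-methylpiperazin-1-yl group, but with pyrrolidin-1-yl in its place the recovery is only partial. Pyrrolidin-1-yl and piperidin-1-yl, which the earlier compounds did not set against each other directly, are not interchangeable at this saturated chain carbon: the step of a 3.0-fold higher number from compound 1 to compound 4 (0.47 log units; beyond the scatter) lies beyond the scatter. Within the data shown here, with pyrrolidin-1-yl held fixed, hydrogen in place of methyl on the oxygen next to the carbonyl group gives a 7.2-fold higher number from compound 2 to compound 4 (0.86 log units; beyond the scatter), the first direct reading of the acid against the ester, so this second site also moves the number. No measurement at hand accounts for any of these steps.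

The compounds shown leave open whether the ester keeps its lower number when piperidin-1-yl or 4-methylpiperazin-1-yl stands on that carbon. They also leave open how a morpholin-4-yl ring or a dimethylamino group would read on the same carbon, and how a primary amide would read in place of the carboxylic acid.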